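The source may hold more compounds than are shown below. What is called first, only, known or untested is meant among the compounds shown, and "the series" means these compounds.

Within the data shown here, compound 1 `Cc1ccccc1-c1cc(C#Cc2ccc(CCC(=O)O)cc2)ccn1` gives 1070 nM in an in vitro functional assay on 1321-N1 cells for agonist activity at Free fatty acid receptor 1 (Homo sapiens), read by fluorescence, spectrophotometry and calcium flux (on this read-out lower numbers stand for an effect already at smaller amounts and higher numbers for an effect only at larger amounts of compound), the second highest of the three numbers measured so far. Compound 2 `O=C(O)CCc1ccc(C#Cc2ncccc2[N+](=O)[O-])cc1` gives 11000 nM, a higher number that lies beyond the scatter, while compound 3 `O=C(O)C1CC1c1ccc(C#Cc2cc(Cl)nc(Cl)c2)cc1` gives 42.7 nM, a lower number that also lies beyond the scatter. Compound 4 `O=C(O)CCc1ccc(C#Cc2ccnc(Oc3ccccc3)c2)cc1` differs from compound 1 by phenoxy in place of 2-methylphenyl on an aromatic carbon. Among the measured compounds shown here, no measured pair shows this particular change, so its effect can only be anticipated. The step of a 1.3-fold lower number from compound 1 to compound 4 (0.13 log units; within the scatter) is expected to be modest, with no clear direction beyond the scatter. For compound 4 the estimated value is 800 nM, within a range from 250 nM to 3000 nM.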

Compound 4, half-maximal effective concentration: 479 nM
The estimate for compound 4 lay 1.7-fold (0.22 log units) above the measured number, within the range that was stated.
By their numbers in this assay, from the lowest: compound 3; then compound 4; then compound 1; then compound 2.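

Swapping 2-methylphenyl for phenoxy on the aromatic carbon next to the ring nitrogen gives a 2.2-fold lower number from compound 1 to compound 4 (0.35 log units; beyond the scatter) in this assay. This position therefore accepts a ring joined through an oxygen, and the number moves modestly towards an effect at smaller amounts. Nothing available explains this shift.

The step removes the methyl and adds the oxygen link together, so their separate contributions cannot be told apart. On these data alone, a plain phenyl group at this place would help separate them, and whether larger groups are accepted here also remains open.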